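Cyano for tert-butoxycarbonyl: notes on the series

The source may hold more compounds than are shown below. What is called first, only, known or untested is meant among the compounds shown, and "the series" means these compounds.

In a functional assay on A549 cells (Homo sapiens) for inhibition, read by MTT assay, with a stated time of 72 h (on this read-out higher numbers stand for weaker inhibition of growth and lower numbers for stronger inhibition of growth), compound 1 (`CC1(C)CCC[C@]2(C)[C@@H](C=O)C(C=O)=CC[C@@H]12`) gives 90000 nM and compound 2 (`CC(C)(C)OC(=O)/C=C/C1=CC[C@H]2C(C)(C)CCC[C@]2(C)[C@H]1C=O`) gives 29000 nM as the lower of the two numbers, a gap that lies beyond the scatter. Going by the values given here, compound 2 therefore stands as the stronger growth inhibitor of the two measured so far. Compound 3 (`CC1(C)CCC[C@]2(C)[C@@H](C=O)C(/C=C/C#N)=CC[C@@H]12`) carries cyano in place of tert-butoxycarbonyl on a double-bonded chain carbon bound to a double-bonded chain carbon and keeps the rest of compound 2 unchanged. Among the compounds with values here, no measured pair shows this exchange, so the data offer no direct guide to its size or direction. The estimated 1.2-fold lower number from compound 2 to compound 3 (0.06 log units; within the scatter) is expected to stay within the scatter, with no firm direction. For compound 3 the estimate is 25000 nM with an expected range from 8000 nM to 80000 nM on this read-out.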

Compound 3, concentration for 50% growth inhibition: 27000 nM
Estimate against measurement, compound 3: 1.1-fold (0.03 log units) below; low and high end bracket the measured number.
By their numbers in this assay, from the lowest: compounds 3 and 2 (each within the scatter of the next); then compound 1.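

In this assay the exchange of tert-butoxycarbonyl for cyano on a double-bonded chain carbon bound to a double-bonded chain carbon gives a 1.1-fold lower number from compound 2 to compound 3 (0.03 log units; within the scatter). At this position, then, a group of 2 heavy atoms and one of 7 cannot be told apart on this read-out, so the large ester is not required to keep the level of compound 2. The other step, 2-cyanoethenyl in place of formyl on a double-bonded ring carbon, gives a 3.3-fold lower number from compound 1 to compound 3 (0.52 log units; beyond the scatter), and nothing at hand accounts for either step.

From the compounds shown here alone, whether a carboxylic acid, an amine or a longer chain in place of cyano would hold this level remains open. Also open, going by these compounds, is whether the remaining formyl group on the shared core contributes to growth inhibition.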